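Shortening the ester chain of compound 1

This account rests on a few compounds, and the source may have more. Where it says the series, first, only, none or still open, it means among the compounds named here.

Values in a functional assay on SK-BR-3 cells (Homo sapiens) for antiproliferative activity, read by MTT assay, with a stated time of 72 h (a higher number here means a weaker inhibitor, a lower number a stronger inhibitor), follow
Compound 1 `C/C=C1/[C@H](O[C@@H]2O[C@H](COC(C)=O)[C@@H](OC(C)=O)[C@H](OC(C)=O)[C@H]2OC(C)=O)OC=C(C(=O)OC)[C@H]1CC(=O)OCCC(C)C` gives > 15000 nM
Compound 2 `C=C(C)CCOC(=O)C[C@@H]1C(C(=O)OC)=CO[C@@H](O[C@@H]2O[C@H](CO)[C@@H](O)[C@H](O)[C@H]2O)/C1=C/C` gives > 15000 nM

Compound 1 has no numerical value in this assay and stands only at a limit of the assay (> 15000 nM). Compound 2 likewise stands at a limit (> 15000 nM). Both measured compounds therefore share the same position (the limit of > 15000 nM in this assay, at which 2 of the 2 values shown sit) and offer no measured step to reason from.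

Compound 3 `C/C=C1/[C@H](O[C@@H]2O[C@H](COC(C)=O)[C@@H](OC(C)=O)[C@H](OC(C)=O)[C@H]2OC(C)=O)OC=C(C(=O)OC)[C@H]1CC(=O)OCC` keeps the core of compound 1 and differs in the ester chain (hydrogen in place of isopropyl on a saturated chain carbon, two bonds along the chain from an oxygen next to a carbonyl group). Hydrogen takes the place of isopropyl on a saturated chain carbon, two bonds along the chain from an oxygen next to a carbonyl group, so isopentyloxy becomes ethoxy.

No step beyond the usual scatter is expected in this assay, and no direction is favoured. Compound 3 may well be reported only as a limit too. The expected change is (a step that the limit leaves unreadable from compound 1 to compound 3) and remains a rough one. For compound 3 the estimated value is (20000 nM) within an expected range (8000 nM to 50000 nM).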

Compound 3, half-maximal inhibitory concentration: > 15000 nM
Compound 3 was reported as a limit; the forecaster's own chance of this, stated with the estimate: 80%; the middle value lies beyond the limit too.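

Compound 1 and compound 3 both stand only at a limit of this assay, so no step can be read between them, and shortening isopentyloxy to ethoxy shows no readable change: the limit of > 15000 nM in this assay, at which 3 of the 3 values shown sit.

The compounds shown leave open whether any ester chain on the shared core would give a numerical value in this assay.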